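A few compounds are considered here, and "the series" means these few. Any claim that something is new, unique, unknown or untested is made for them only; others in the source may bear on it.

Compound 1 `Nc1ccccc1NC(=O)c1ccc(NC(=O)NCc2cccnc2)cc1`: > 100000 nM
Compound 2 `Nc1ccccc1NC(=O)c1ccc(NC(=O)NCc2ccc(Cl)nc2)cc1`: 34000 nM
Compound 3 `Nc1ccccc1NC(=O)c1ccc(NC(=O)NCc2ccc(F)nc2)cc1`: 91000 nM

All three results come from a functional assay on MDA-MB-231 cells (Homo sapiens) for cytotoxicity, read by MTT assay, with a stated time of 72 h; a lower number here means a stronger inhibitor, a higher number a weaker inhibitor. Compound 1 gives > 100000 nM, which is a limit of the assay and not a number. Among the compounds with values here, of the two true numbers, the one for compound 3 is the higher, so compound 3 is the weaker inhibitor of that pair.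

The next compound is compound 4 `Nc1ccc(CNC(=O)Nc2ccc(C(=O)Nc3ccccc3N)cc2)cn1`. It differs from compound 3 at one place: amino in place of fluoro on an aromatic carbon. Put simply, the 6-fluoropyridin-3-yl group of compound 3 becomes a 6-aminopyridin-3-yl group in compound 4.

No amino group has been measured here, so the guide is the other swaps at this carbon. With chloro in place of hydrogen there is an at least 2.9-fold lower number from compound 1 to compound 2 (0.46 log units; beyond the scatter). With fluoro in place of hydrogen there is an at least 1.0-fold lower number from compound 1 to compound 3 (0.04 log units; that floor lies within the scatter). With fluoro in place of chloro there is a 2.7-fold higher number from compound 2 to compound 3 (0.43 log units; beyond the scatter). These steps are small, and none involves amino, so no change beyond the scatter is expected in this assay. The expected change is a 1.3-fold lower number from compound 3 to compound 4 (0.11 log units; within the scatter). The estimate for compound 4 is 70000 nM, with an expected range from 30000 nM to 120000 nM.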

Compound 4, half-maximal inhibitory concentration: > 100000 nM
Compound 4: only a limit was reported (the forecaster's own chance of this, stated with the estimate: 35%); middle value at least 1.4-fold (0.15 log units) away from the limit.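

In this assay, compound 4 gives > 100000 nM, which is a limit of the assay and not a number, and it is not alone there: the limit of > 100000 nM in this assay, at which 2 of the 4 values shown sit.

Amino is the first group at this carbon to add a hydrogen-bond donor and acceptor, yet it brings no sign of the gain seen with chloro, since amino in place of chloro gives an at least 2.9-fold higher number from compound 2 to compound 4 (0.46 log units; beyond the scatter). Amino in place of fluoro gives an at least 1.0-fold higher number from compound 3 to compound 4 (0.04 log units; that floor lies within the scatter), so this result cannot separate amino from fluoro, and the step between compound 1 and compound 4 cannot be read at all.

Chloro therefore remains the only group shown here with a step beyond the scatter from the unsubstituted pyridine of compound 1, but a single such group does not make a trend. Going by these compounds, whether a bromo, methyl or methoxy group at this carbon would match or pass chloro stays open, as does how a dimethylamino or acetamido group would compare with the plain amino group of compound 4.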